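The source may hold more compounds than are shown below. What is called first, only, known or untested is meant among the compounds shown, and "the series" means these compounds.

The compounds here share one core and differ in the group on a saturated chain carbon bound to an amine nitrogen in a ring. Going by the values given here, in an ADME assay on Vero cells (Chlorocebus sabaeus) for cytotoxicity, read by MTT assay, with a stated time of 72 h (on this read-out higher numbers stand for lower toxicity in this test and lower numbers for higher toxicity in this test), compound 1 `COc1c(N2CCN(CCC#N)C(C)C2)c(F)cc2c(=O)c(C(=O)O)cn(C3CC3)c12` gives 500 ug/mL and compound 3 `COc1c(N2CCN(C/C(C)=N/NC(N)=O)C(C)C2)c(F)cc2c(=O)c(C(=O)O)cn(C3CC3)c12` gives 500 ug/mL, so compound 3 stands level with the only other compound that has a number. Compound 2 `CCOC(=O)CCN1CCN(c2c(F)cc3c(=O)c(C(=O)O)cn(C4CC4)c3c2OC)CC1C` adds nothing here, as its entry reads "not determined" (no result reported). Compound 4 `COc1c(N2CCN(CC/C(C)=N/O)C(C)C2)c(F)cc2c(=O)c(C(=O)O)cn(C3CC3)c12` is still unmeasured, and it differs from compound 3 in one place: a group of 5 heavy atoms (3 carbon, 1 nitrogen, 1 oxygen; no ring) in place of a group of 7 heavy atoms (3 carbon, 3 nitrogen, 1 oxygen; no ring), on a saturated chain carbon bound to an amine nitrogen in a ring. Among the compounds with values here, the only measured step that bears on this is no change at the digits printed from compound 1 to compound 3 (within the scatter), a swap at that same place, and it gives no reason to expect a shift for compound 4. One step is thin evidence, and the group entering compound 4 has not been tested in any other compound here. The expected size of the change in this assay is no change at the digits printed from compound 3 to compound 4 (within the scatter), which means none beyond the scatter. For compound 4 the estimated value is 500 ug/mL, with an expected range from 280 ug/mL to 800 ug/mL.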

Compound 4, half-maximal cytotoxic concentration: 44.2 ug/mL
For compound 4 the middle estimate is 11-fold (1.05 log units) above the measured one, and the stated range ends above it.
By their numbers in this assay, from the lowest: compound 4; then compounds 1 and 3 (each within the scatter of the next).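

This position is not indifferent to what sits on it in this assay: the swap gives an 11-fold lower number from compound 3 to compound 4 (1.05 log units; beyond the scatter), and the comparison with the other measured compound gives an 11-fold lower number from compound 1 to compound 4 (1.05 log units; beyond the scatter). Going by these compounds alone, since a lower number in this test stands for higher toxicity, compound 4 is the one compound here that separates from the others, so the level reading of the two earlier compounds does not extend to every group at this place. Nothing measured here bears on why the number drops.

The compounds shown leave open which part of the group entering compound 4 goes with the lower number, and whether a plain ketone, an amine or a longer chain at the same place would also lower it. Within the data shown here, with only three numbers, this remains a single sharp drop and not a trend.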